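The compounds below may be only part of what the source reports. "The series", "measured", "known", "first", "only" and "open" are said of these compounds alone.

Measured in a functional assay on HCT-116 cells (Homo sapiens) for inhibition, read by MTT assay, with a stated time of 72 h; a higher number here means a weaker inhibitor, a lower number a stronger inhibitor:
Compound 1 `CCOC(=O)c1oc2ccc(N(Cc3ccccc3)S(=O)(=O)c3ccc(Br)cc3)cc2c1C` gives 9460 nM.
Compound 2 `CCOC(=O)c1oc2ccc(N(Cc3ccccc3)S(=O)(=O)c3ccccc3Br)cc2c1C` reaches only the limit of this assay, > 40000 nM.

Compound 2 thus stands at the upper edge of what this assay reports (the limit of > 40000 nM in this assay, at which 1 of the 2 values shown sits), so only a range is known for it. Compound 3 `CCOC(=O)c1oc2ccc(N(Cc3ccccc3)S(=O)(=O)c3ccc(C(F)(F)F)cc3)cc2c1C` differs in 4-(trifluoromethyl)phenyl in place of 2-bromophenyl on a sulfonyl sulfur. For the measured compounds named here, the one measured step that bears on this change, an at least 4.2-fold higher number from compound 1 to compound 2 (0.62 log units; beyond the scatter), ran toward the limit when 4-bromophenyl became 2-bromophenyl; compound 3 returns to a group patterned like the 4-bromophenyl of compound 1, so a step back toward the value of compound 1 is expected, though a limit remains possible. Compound 3 is expected at 12000 nM (range 4000 nM to 40000 nM). The expected step is an at least 3.3-fold lower number from compound 2 to compound 3 (0.52 log units; beyond the scatter).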

Compound 3, half-maximal inhibitory concentration: 26700 nM
Estimate against measurement, compound 3: 2.2-fold (0.35 log units) below; the range from low to high includes it.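

The value of compound 2 is a limit of this assay, not a number: the limit of > 40000 nM in this assay, at which 1 of the 3 values shown sits.

Read against that limit, an at least 1.4-fold lower number from compound 2 to compound 3 (0.17 log units; that floor lies within the scatter), so this step alone shows no firm gain. The firmer reading is that the 4-(trifluoromethyl)phenyl group does not match the 4-bromophenyl group on the sulfonyl sulfur, with a 2.8-fold higher number from compound 1 to compound 3 (0.45 log units; beyond the scatter).

The compounds shown leave open how a methoxy group or an amine in place of bromo on an aromatic carbon would read, and whether any such group would better compound 1.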